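The source may report more compounds than this note shows. Statements on the series, on what has been measured and on what is new or still open speak of the compounds shown alone.

Among the compounds with values here, compound 3, `CCn1c(SCC(=O)Nc2ccc(C(C)=O)cc2)nnc1-c1ccc(OC)c(OC)c1`, is one of three compounds measured in a functional assay on the whole organism (strain albino) for inhibition, with Rattus norvegicus as the target, read by paw edema, with stated times of 30 min and 2 h, at a dose of 0.28 mmol/kg by the oral route; a higher number here means more inhibition at the dose given (going by the name of the read-out), a lower number less inhibition. In that assay compound 3 gives 59%, the second highest of the three numbers. Within the data shown here, compound 2, `CCn1c(SCC(=O)Nc2ccc(/C(C)=N/O)cc2)nnc1-c1ccc(OC)c(OC)c1`, gives 65%, and the single change a number 6 percentage points lower from compound 2 to compound 3 (within the scatter) lies within the scatter. Compound 1, `C=CCn1c(SCC(=O)Nc2ccc(C(C)=O)cc2)nnc1-c1ccccc1`, gives 52%; compound 1 differs from compound 3 in two places, so only the two values themselves can be compared, and they lie within the scatter of each other.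

Compound 4, `C=CCn1c(SCC(=O)Nc2ccc(C(C)=O)cc2)nnc1-c1ccc(OC)c(OC)c1`, differs from compound 3 by vinyl in place of methyl on a saturated chain carbon bound to an aromatic nitrogen. Among the measured compounds shown here, no measured pair differs by exactly this change, so no step bears on it directly; the only related fact is that compound 1 already carries the allyl group and sits within the scatter of compound 3. A step beyond the scatter is therefore not expected, and compound 4 is estimated to show no change at the digits printed from compound 3 to compound 4 (within the scatter). For compound 4 the value in this assay is expected to be about 59%, ranging from 45% to 72%.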

Compound 4, a percentage reported as inhibition, in the whole organism at one dose (the size of the read-out at that dose, not a potency): 57%
Beside the measured number, compound 4's estimate is 2 percentage points above it; the measured number falls inside the stated range.
By their numbers in this assay, from the lowest: compounds 1, 4, 3 and 2 (each within the scatter of the next, the first and the last beyond it).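

In this assay the position on the saturated chain carbon bound to an aromatic nitrogen now has its first direct reading, a number 2 percentage points lower from compound 3 to compound 4 (within the scatter), so vinyl in place of methyl, which also reads as ethyl to allyl, stays within the scatter on the 3,4-dimethoxyphenyl compounds. The aromatic carbon has a direct reading too, a number 5 percentage points higher from compound 1 to compound 4 (within the scatter), so with the allyl group in place, 3,4-dimethoxyphenyl in place of phenyl also stays within the scatter. Nothing measured here gives a reason for either step.

From the compounds shown here alone, whether a group of another kind on this chain, such as a dimethylamino group or a carboxylic acid, would step beyond the scatter remains open. So does whether a longer chain, such as butyl, or a benzyl group would.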